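A Swapped Side Group on an Inactive Core

The source may report more compounds than this note shows. Statements on the series, on what has been measured and on what is new or still open speak of the compounds shown alone.

Of the compounds shown here, two built on the same core have been tested so far. In a functional assay on RAW264.7 cells (Mus musculus) for inhibition, with stated times of 2 h and 24 h (a higher number here means a weaker inhibitor, a lower number a stronger inhibitor), compound 1 `COc1ccc([C@@H]2c3c(OC)cc(OC)cc3/C(=C/c3ccccc3)[C@H]2c2cc(OC)cc(OC)c2)cc1` gives > 200000 nM, which is a limit of the assay and not a number. In this assay, compound 2 `COc1ccc([C@@H]2c3c(OC)cc(OC)cc3C(SCc3ccc(C)cc3)[C@H]2c2cc(OC)cc(OC)c2)cc1` gives > 200000 nM, which is also a limit. Compound 2 therefore has no exact value and stands level with compound 1, and the whole record so far is the limit of > 200000 nM in this assay, at which 2 of the 2 values shown sit.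

The next compound to be tested is compound 3 `COc1ccc(C(O)C2c3cc(OC)cc(OC)c3[C@@H](c3ccc(OC)cc3)[C@@H]2c2cc(OC)cc(OC)c2)cc1`. It replaces the (4-methylbenzyl)sulfanyl group of compound 2 with hydroxy(4-methoxyphenyl)methyl on a saturated ring carbon, and the change counts as follows: hydroxy(4-methoxyphenyl)methyl in place of (4-methylbenzyl)sulfanyl on a saturated ring carbon.

Within the data shown here, no measured pair shows what such a swap does. I expect no step beyond the usual scatter in this assay, in either direction, and this expectation rests on compound 2, which gives > 200000 nM, a limit. The expected change is a number no higher from compound 2 to compound 3 (the limit leaves the size open). For compound 3 the estimated value is 200000 nM, with an expected range from 60000 nM to 400000 nM.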

Compound 3, half-maximal inhibitory concentration: > 200000 nM
Compound 3 was reported as a limit; the forecaster's own chance of this, stated with the estimate: 65%; the middle value lies on the limit itself.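

Among these compounds, compound 2 and compound 3 both give only a limit in this assay, so no step between them can be read. The whole record now comes down to one point: the limit of > 200000 nM in this assay, at which 3 of the 3 values shown sit. The compounds shown leave open whether any change on the shared core can give an exact value, and which change that would be.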